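The source may hold more compounds than are shown below. What is called first, only, known or untested is meant among the compounds shown, and "the series" means these compounds.

Measured compounds:
compound 1 `CN(C)C(=O)c1cc2cnc(Nc3ccc(NC(=O)C4(C(=O)Nc5ccc(F)cc5)CC4)cc3F)nc2n1C1CCCC1` — 49.5%
compound 2 `CN(C)C(=O)c1cc2cnc(Nc3ccc(NC(=O)C4(C(=O)Nc5ccc(Cl)c(C(F)(F)F)c5)CC4)cc3)nc2n1C1CCCC1` — 55.6%
compound 3 `Nc1ccc(NC(=O)C2(C(=O)Nc3ccc(F)cc3)CC2)cc1F` — 71.8%

In a functional assay on HeLa cells (Homo sapiens) for inhibition, read by CCK-8 assay, with a stated time of 72 h, tested at 10 uM (a lower number here means less inhibition of growth, a higher number more inhibition of growth at the concentration tested), compound 2 gives 55.6%, the second highest of the three numbers. Its nearest neighbour is compound 1 at 49.5%, a gap within the scatter; compound 3 at 71.8% stands furthest away, beyond the scatter. The unmeasured compound 4 `CN(C)C(=O)c1cc2cnc(Nc3ccc(NC(=O)C4(C(=O)Nc5ccc(F)cc5)CC4)cc3)nc2n1C1CCCC1` differs from compound 2 in one place: 4-fluorophenyl in place of 4-chloro-3-(trifluoromethyl)phenyl on an amide-type nitrogen. Going by the values given here, no pair of measured compounds shows this change on its own, so the expected step from compound 2 to compound 4 in this assay is set as none beyond the scatter, leaning slightly downward: a number 5.6 percentage points lower from compound 2 to compound 4 (within the scatter). Compound 4 is therefore expected to give 50%, between 35% and 65%.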

Compound 4, percent growth inhibition at one concentration: 73.7%
The estimate for compound 4 lay 23.7 percentage points below the measured number; measured number above the stated range.
By their numbers in this assay, from the lowest: compounds 1 and 2 (each within the scatter of the next); then compounds 3 and 4 (each within the scatter of the next).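

In this assay, 4-fluorophenyl in place of 4-chloro-3-(trifluoromethyl)phenyl on the amide-type nitrogen gives a number 18.1 percentage points higher from compound 2 to compound 4 (beyond the scatter), so the group at this position does change growth inhibition. Hydrogen in place of fluoro on an aromatic carbon gives a number 24.2 percentage points higher from compound 1 to compound 4 (beyond the scatter), so that single replacement changes it too. Nothing measured here accounts for either step. Whether the chloro or the trifluoromethyl carries the first step stays open, since neither stands alone on that ring in the compounds shown. Going by these compounds, how a methoxy group or an amine on that ring would read also remains open.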